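Changing the amide chain in a cytotoxicity series

The source may report more compounds than this note shows. Statements on the series, on what has been measured and on what is new or still open speak of the compounds shown alone.

In an ADME assay on L02 cells (Homo sapiens) for cytotoxicity, read by MTT assay, with a stated time of 48 h (on this read-out higher numbers stand for weaker inhibition and lower numbers for stronger inhibition), compound 1 (`CCn1c(C(=O)NCCN)ccc1C(CC)(CC)c1ccc(OCC(=O)C(C)(C)C)c(C)c1`) gives 2500 nM and compound 2 (`CCn1c(C(=O)NCCN)ccc1C(CC)(CC)c1ccc(OCC(O)C(C)(C)C)c(C)c1`) gives 2400 nM. The step of a 1.0-fold lower number from compound 1 to compound 2 (0.02 log units; within the scatter) lies within the scatter, so compound 2 sits level with compound 1 and the two cannot be ranked.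

Compound 3 (`CC[C@@H](C)[C@H](NC(=O)c1ccc(C(CC)(CC)c2ccc(OCC(O)C(C)(C)C)c(C)c2)n1CC)C(=O)O`) differs from compound 2 in one place: 1-carboxy-2-methylbutyl in place of 2-aminoethyl on an amide-type nitrogen. In words, 1-carboxy-2-methylbutyl stands in place of 2-aminoethyl on an amide-type nitrogen. Within the data shown here, the single measured step concerns another group, so it sets no size for this change, and no measured compound carries the new chain. The expectation is therefore a judgement resting on the exchange of a short amino chain for a longer carboxy one, and it points towards a higher number, meaning weaker inhibition. The expected step is a 6.3-fold higher number from compound 2 to compound 3 (0.80 log units; beyond the scatter). The estimated value for compound 3 is 15000 nM, within an expected range of 4000 nM to 50000 nM.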

Compound 3, half-maximal inhibitory concentration: 1400 nM
Beside the measured number, compound 3's estimate is 11-fold (1.03 log units) above it, outside the stated range (below it).
By their numbers in this assay, from the lowest: compounds 3, 2 and 1 (each within the scatter of the next).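

In this assay, the exchange of 2-aminoethyl for 1-carboxy-2-methylbutyl on the amide-type nitrogen amounts to a 1.7-fold lower number from compound 2 to compound 3 (0.23 log units; within the scatter), so the two compounds cannot be ranked. Among these compounds, the earlier pair changed a different group, which makes this the first reading at this position. Here the chain grows from 3 to 8 heavy atoms, loses its nitrogen, and gains a carboxy group and 2 defined stereocentres, yet the number stays level, so in this pair the position tolerates a large change of chain.

The data shown offer no measurement that accounts for this outcome. On these data alone, it remains open whether a longer amine such as 3-aminopropyl, or a shorter acid such as carboxymethyl, would also stay level with compound 2.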